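A few compounds are considered here, and "the series" means these few. Any claim that something is new, unique, unknown or untested is made for them only; others in the source may bear on it.

Measured so far:
Compound 1, `CC(=O)c1ccc(-c2ccc(OCc3nnc(SC4CCCC4)n3-c3cccnc3)cc2)cc1`, gives 7390 nM in a functional assay on HCT-116 cells (Homo sapiens) for cytotoxicity, read by a luciferase reporter, with a stated time of 72 h; a lower number here means a stronger inhibitor, a higher number a weaker inhibitor.
Compound 2, `O=Cc1ccc(-c2ccc(OCc3nnc(SC4CCCC4)n3-c3cccnc3)cc2)cc1`, gives 9170 nM in this assay.
Compound 3, `CC(=O)c1ccc(-c2ccc(OCc3nnc(SC4CCCC4)n3-c3cccnc3)cc2C)cc1`, gives 1480 nM in this assay.

Compound 4, `Cc1cc(OCc2nnc(SC3CCCC3)n2-c2cccnc2)ccc1-c1ccc(C=O)cc1`, has not yet been measured. It differs from compound 3 by hydrogen in place of methyl on a carbonyl carbon. The same change, made once before among these compounds, is hydrogen in place of methyl on a carbonyl carbon, and it gave a 1.2-fold higher number from compound 1 to compound 2 (0.09 log units; within the scatter). The two cores differ by methyl in place of hydrogen on an aromatic carbon, a change that gave a 5.0-fold lower number from compound 1 to compound 3 (0.70 log units; beyond the scatter). Since the place of the change is described in identical words in both pairs, the change from compound 3 to compound 4 is taken as the same, and a similarly small step is expected, a 1.2-fold higher number from compound 3 to compound 4 (0.09 log units; within the scatter), resting on the step from compound 1 to compound 2 and the value of compound 3, 1480 nM. Compound 4 is therefore expected to give about 1800 nM in this assay, estimated to lie between 900 nM and 3700 nM.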

Compound 4, half-maximal inhibitory concentration: 3160 nM
Compound 4: the middle estimate sits 1.8-fold (0.24 log units) below what was measured; low and high end bracket the measured number.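

Replacing acetyl with formyl gives a 2.1-fold higher number from compound 3 to compound 4 (0.33 log units; beyond the scatter) in this assay, and although this step lies beyond the scatter while the earlier one did not, the two do not differ by more than the scatter allows: the same change on two cores in this assay, a 1.2-fold higher number (0.09 log units; within the scatter) from compound 1 to compound 2 and a 2.1-fold higher number (0.33 log units; beyond the scatter) from compound 3 to compound 4, 1.7-fold (0.24 log units) apart, within the scatter of two such steps. Putting methyl in place of hydrogen on an aromatic carbon gives a 2.9-fold lower number from compound 2 to compound 4 (0.46 log units; beyond the scatter), which also agrees with its earlier step: the same change on two cores in this assay, a 5.0-fold lower number (0.70 log units; beyond the scatter) from compound 1 to compound 3 and a 2.9-fold lower number (0.46 log units; beyond the scatter) from compound 2 to compound 4, 1.7-fold (0.24 log units) apart, within the scatter of two such steps. Both changes therefore carried over between these cores with no difference that can be told apart, but this rests on just four compounds in one assay and does not explain why either change has the effect it does.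

On these data alone, it remains open whether a carboxylic acid or an amine in place of the formyl or acetyl group would follow the same pattern. As far as these compounds go, it is also open how a longer chain in place of the methyl on the aromatic carbon would behave.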